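The source may report more compounds than this note shows. Statements on the series, on what has been measured and on what is new or still open speak of the compounds shown alone.

Compound 1 `CNC(=O)c1cccc(Cn2nc(C)c(NC(=O)c3ccc(COc4ccccc4C)cc3)c2C)c1`: 2100 nM in a functional assay on MIA PaCa-2 cells (Homo sapiens) for antiproliferative activity, read by MTT assay, with a stated time of 72 h; a lower number here means that less compound is needed, a higher number that more compound is needed for the effect
Compound 2 `CNC(=O)c1cccc(Cn2nc(C)c(NC(=O)c3ccc(COc4cccc(C)c4)cc3)c2C)c1`: 6200 nM in this assay

Compound 2 holds the highest of the two numbers in this assay; its nearest neighbour is compound 1, and the step of a 3.0-fold higher number from compound 1 to compound 2 (0.47 log units; beyond the scatter) lies beyond the scatter. Compound 3 `CNC(=O)c1cccc(Cn2nc(C)c(NC(=O)c3ccc(COc4ccc(C)cc4)cc3)c2C)c1` differs from compound 2 by 4-methylphenyl in place of 3-methylphenyl on an oxygen on a saturated carbon, that is, 3-methylphenoxy to 4-methylphenoxy. No measured step covers this change; the only step shown, a 3.0-fold higher number from compound 1 to compound 2 (0.47 log units; beyond the scatter), also exchanged one methylphenyl for another and was modest. A modest step in either direction, or none beyond the scatter, is plausible. Compound 3 is therefore estimated at 5000 nM, within 1500 nM to 15000 nM, in this assay. That estimate means an expected step of a 1.2-fold lower number from compound 2 to compound 3 (0.09 log units; within the scatter).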

Compound 3, half-maximal effective concentration: 2600 nM
Compound 3: middle estimate off by 1.9-fold (0.28 log units), on the high side, within the range that was stated.
By their numbers in this assay, from the lowest: compounds 1 and 3 (each within the scatter of the next); then compound 2.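

Exchanging 3-methylphenyl for 4-methylphenyl on this oxygen gives a 2.4-fold lower number from compound 2 to compound 3 (0.38 log units; beyond the scatter), so the number in this assay can change with where the methyl sits on the ring, even though the atoms stay the same. Exchanging 2-methylphenyl for 4-methylphenyl gives a 1.2-fold higher number from compound 1 to compound 3 (0.09 log units; within the scatter), so these two cannot be told apart, and among these three only the 3-methylphenyl group of compound 2 stands out. Nothing measured here explains this difference.

All three compounds carry only a methyl on this ring. On these data alone, how a chlorine, a methoxy group or an amine would read there stays open, as does a ring with no methyl at all.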